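Series notes: amide substituent and whole-organism inhibition

The source may report more compounds than this note shows. Statements on the series, on what has been measured and on what is new or still open speak of the compounds shown alone.

The three measured compounds share one core and differ only in the group on the carbonyl carbon. Compound 1 `O=C(/C=C1\CCc2ccc(F)cc21)NCC1CC1` carries a (cyclopropylmethyl)amino group and in a functional assay on the whole organism with Rattus norvegicus as the target, at a dose of 20 mg/kg by the oral route (on this read-out lower numbers stand for less inhibition and higher numbers for more inhibition at the one dose given (going by the name of the read-out)), compound 1 gives 0%. Compound 2 `O=C(/C=C1\CCc2ccc(F)cc21)NCCO` carries a (2-hydroxyethyl)amino group, and compound 2 gives 42%. Compound 3 `CON(C)C(=O)/C=C1\CCc2ccc(F)cc21` carries a methoxy(methyl)amino group, and compound 3 gives 6%. Among the three numbers compound 3 stands second highest; its nearest neighbour is compound 1, with a number 6 percentage points higher from compound 1 to compound 3 (within the scatter), and its furthest is compound 2, with a number 36 percentage points lower from compound 2 to compound 3 (beyond the scatter).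

Compound 4 `O=C(/C=C1\CCc2ccc(F)cc21)NC1CC1` is not yet measured. The change from compound 3 is cyclopropylamino in place of methoxy(methyl)amino on a carbonyl carbon. Among the compounds with values here, two measured steps bear on this: the change from compound 1 to compound 3 was a number 6 percentage points higher from compound 1 to compound 3 (within the scatter), so exchanging a cyclopropyl-bearing amino group for methoxy(methyl)amino moved little, whereas the change from compound 2 to compound 3 was a number 36 percentage points lower from compound 2 to compound 3 (beyond the scatter). Compound 4 resembles compound 1 more than compound 2, so a small step, if any, is expected, likely within the scatter. The expected step is a number 4 percentage points higher from compound 3 to compound 4 (within the scatter). Compound 4 is therefore estimated at 10%, with a range from 0% to 35%.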

Compound 4, a percentage reported as inhibition, in the whole organism at one dose (the size of the read-out at that dose, not a potency): 5%
Compound 4: middle estimate off by 5 percentage points, on the high side; measured number inside the range.
By their numbers in this assay, from the lowest: compounds 1, 4 and 3 (each within the scatter of the next); then compound 2.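

Cyclopropylamino in place of methoxy(methyl)amino on the carbonyl carbon gives a number 1 percentage points lower from compound 3 to compound 4 (within the scatter) in this assay, so at this position a swap between groups of equal heavy-atom count, from no hydrogen-bond donor to one, does not separate the two compounds. Cyclopropyl in place of cyclopropylmethyl on the amide-type nitrogen gives a number 5 percentage points higher from compound 1 to compound 4 (within the scatter), which adds that the ring placed directly on that nitrogen reads the same, within the scatter, as the ring carried on the longer group. Cyclopropyl in place of 2-hydroxyethyl gives a number 37 percentage points lower from compound 2 to compound 4 (beyond the scatter), a second large step to compound 2 from a cyclopropyl-bearing amide, which leaves compound 2 as the only one of the four standing apart from the rest.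

Whether that gap follows the free hydroxyl or the open chain as such stays unsettled, and a 2-methoxyethyl, 3-hydroxypropyl or 2-aminoethyl group on the same nitrogen would bear on it. No measurement at hand accounts for the gap between 2-hydroxyethyl and the other three groups.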